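This account rests on a few compounds, and the source may have more. Where it says the series, first, only, none or still open, it means among the compounds named here.

Two members of the series carry numbers in a functional assay on the whole organism (stomach) for inhibition, with Canis familiaris (Canis lupus familiaris) as the target, at a dose of 5 mg/kg by the intravenous route; on this read-out higher numbers stand for a stronger effect at the one dose given and lower numbers for a weaker effect. Compound 1 `COCc1c(C)nc2c(OCc3ccccc3)cccn12` gives 29% in this assay. Going by the values given here, compound 2 `Cc1nc2c(OCc3ccccc3)cccn2c1C[S+](C)[O-]` gives 18% in this assay, the lowest of the two numbers; its nearest neighbour is compound 1, and the sole measured step, a number 11 percentage points lower from compound 1 to compound 2 (beyond the scatter), is a modest drop beyond the scatter on putting a group of 3 heavy atoms in place of a group of 2 heavy atoms on a saturated chain carbon bound to an aromatic carbon.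

Compound 3 `Cc1nc2c(OCc3ccccc3)cccn2c1Cl` is not yet measured. one chlorine atom in place of a group of 4 heavy atoms (2 carbon, 1 oxygen, 1 sulfur; no ring), on an aromatic carbon The change sits on an aromatic carbon of a five-membered aromatic ring with 2 nitrogen, part of a fused or bridged system of two rings. Among the compounds with values here, no measured step exchanges such a chain for a single chlorine; the step of a number 11 percentage points lower from compound 1 to compound 2 (beyond the scatter) bears on it only in that the group now leaving is the one whose entry lowered the number. Some of that loss is therefore expected to return, and for compound 3 the expected step is a number 7 percentage points higher from compound 2 to compound 3 (within the scatter) in this assay, upward but not firmly beyond the scatter. Compound 3 is estimated at 25%, within 5% to 50%.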

Compound 3, a percentage reported as inhibition, in the whole organism at one dose (the size of the read-out at that dose, not a potency): 37%
Compound 3: middle estimate off by 12 percentage points, on the low side, within the range that was stated.
By their numbers in this assay, from the lowest: compound 2; then compounds 1 and 3 (each within the scatter of the next).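

In this assay, putting one chlorine atom on this aromatic carbon in place of the sulfur-bearing chain gives a number 19 percentage points higher from compound 2 to compound 3 (beyond the scatter) and so reverses the drop seen when that sulfur-bearing chain was introduced. Set against methoxymethyl, the chloro group gives a number 8 percentage points higher from compound 1 to compound 3 (within the scatter) so the two groups cannot be told apart on this read-out, and a chain on this aromatic carbon is therefore not required to hold the number at the level of compound 1. No measurement at hand explains either step.

The compounds shown leave open whether another halogen such as fluorine or bromine, an amine or a carboxylic acid on this aromatic carbon would stay level with chloro or fall towards compound 2, and whether the chloro result would carry over to a change elsewhere on the shared core. On these data alone, each number is also the size of the effect at one intravenous dose and not a potency, so it remains open whether the same ranking would hold across a range of doses.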